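Swapping the Quinoline for an Isoquinoline on the Sulfonyl

The source may report more compounds than this note shows. Statements on the series, on what has been measured and on what is new or still open speak of the compounds shown alone.

Measured so far:
Compound 1, `O=S(=O)(c1cnc2ccccc2c1)n1cc(C2=CCNCC2)c2ccccc21`, gives 13 nM in an assay on HEK293 cells for displacement of a labelled ligand from 5-hydroxytryptamine receptor 6 (Homo sapiens), read by scintillation counting; a higher number here means a weaker inhibitor, a lower number a stronger inhibitor.
Compound 2, `COc1ccc2c(c1)c(C1=CCNCC1)cn2S(=O)(=O)c1cnc2ccccc2c1`, gives 8 nM in this assay.

These two compounds share a core and differ only in a methoxy in place of hydrogen on an aromatic carbon. For the measured compounds named here, the one step measured so far, a 1.6-fold lower number from compound 1 to compound 2 (0.21 log units; within the scatter), is too small to count as a real difference, so compound 2 stands within the usual scatter of compound 1 rather than clearly apart from it.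

Compound 3, `COc1ccc2c(c1)c(C1=CCNCC1)cn2S(=O)(=O)c1cc2ccccc2cn1`, is the next compound. It differs from compound 2 by isoquinolin-3-yl in place of quinolin-3-yl on a sulfonyl sulfur. The two groups have the same atoms joined in a different order, so the change is a rearrangement of the group on the sulfonyl sulfur, not an addition or removal.

Going by the values given here, no measured step speaks to this change: the only step in hand, a 1.6-fold lower number from compound 1 to compound 2 (0.21 log units; within the scatter), concerns the methoxy on the aromatic carbon and says nothing about the sulfonyl group. With nothing to point either way, the expected step of a 1.5-fold higher number from compound 2 to compound 3 (0.18 log units; within the scatter) is one of no change beyond the scatter, and the estimate for compound 3 in this assay is 12 nM, with a range from 4 nM to 40 nM.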

Compound 3, inhibition constant: 6 nM
For compound 3 the middle estimate is 2.0-fold (0.30 log units) above the measured one; the measured number falls inside the stated range.
By their numbers in this assay, from the lowest: compounds 3, 2 and 1 (each within the scatter of the next, the first and the last beyond it).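

In this assay, for the compounds shown here, replacing quinolin-3-yl with isoquinolin-3-yl on the sulfonyl sulfur gives a 1.3-fold lower number from compound 2 to compound 3 (0.12 log units; within the scatter), the first measurement of any change to this group. Rearranging the atoms of this group therefore produces no difference that can be told from ordinary assay scatter, and the group on the sulfonyl sulfur tolerates at least this one change with the methoxy in place. No supporting data bear on why the two groups read alike, so the result describes the outcome without explaining it.

Both groups contain one aromatic ring of carbon only and one aromatic ring with a single nitrogen, so the compounds shown leave open whether that nitrogen matters at all; naphthalen-2-yl, which has carbon in its place, or the smaller phenyl group would test this. Going by these compounds alone, it is also open whether isoquinolin-3-yl would read the same way on the core of compound 1, where hydrogen stands in place of the methoxy, as this change has been seen only on the methoxy-bearing core.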